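Dechlorination within a small triazole series

This account rests on a few compounds, and the source may have more. Where it says the series, first, only, none or still open, it means among the compounds named here.

Measured so far:
compound 1, `FC(F)(F)c1cccc(-n2nncc2-c2ccncc2)c1`, 44.7 mg/kg
compound 2, `Clc1ccc(-n2nncc2-c2cccnc2)cc1`, 27 mg/kg

In a functional assay on the whole organism with Mus musculus as the target (on this read-out lower numbers stand for an effect already at smaller amounts and higher numbers for an effect only at larger amounts of compound), compound 2 gives the lowest of the two numbers; compound 1 stands within the scatter of it, so no order between them is claimed. Compound 3, `c1ccc(-n2nncc2-c2cccnc2)cc1`, has not been measured. It differs from compound 2 by hydrogen in place of chloro on an aromatic carbon. Among the measured compounds shown here, no step between measured compounds informs this change, so the expected step of a 1.3-fold higher number from compound 2 to compound 3 (0.11 log units; within the scatter) is small and of uncertain direction, likely within the scatter. Compound 3 is therefore expected to give 35 mg/kg, with a range of 14 mg/kg to 90 mg/kg.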

Compound 3, dose for half-maximal effect: 39.7 mg/kg
Compound 3: the middle estimate sits 1.1-fold (0.05 log units) below what was measured, and the stated range covers the measured number.
By their numbers in this assay, from the lowest: compounds 2, 3 and 1 (each within the scatter of the next).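

In this assay, hydrogen in place of chloro on an aromatic carbon, para to a large group, gives a 1.5-fold higher number from compound 2 to compound 3 (0.17 log units; within the scatter). Among the compounds shown here, this is the first direct read of this change, and it shows that the chloro group is not required for an effect at doses of this order. No measurement of any property bears on this result.

As far as these compounds go, whether an amine or a methoxy group at this position would move the number beyond the scatter remains open. Also open, from the compounds shown here alone, is whether the same exchange would give a similar step on the core of compound 1.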